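Chlorination on the Aryl Ring of Two Chalcone-Type Cores

The compounds below may be only part of what the source reports. "The series", "measured", "known", "first", "only" and "open" are said of these compounds alone.

Compound 1, `O=C(/C(=C/c1ccc(Cl)cc1)CCl)c1ccccc1`: 3200 nM
Compound 2, `O=C(/C(=C/c1ccc(Cl)cc1Cl)CCl)c1ccccc1`: 3100 nM
Compound 3, `CC(=O)OC/C(=C/c1ccccc1Cl)C(=O)c1ccccc1`: 21000 nM

In a functional assay on HBL-100 cells (Homo sapiens) for inhibition, read by sulforhodamine B assay, with a stated time of 48 h (a higher number here means a weaker inhibitor of growth, a lower number a stronger inhibitor of growth), compound 1 and compound 2 share a core, and compound 3 carries a different one; the difference between the two cores is not broken down here. Compound 3 stands highest of the three, with compound 1 nearest to it.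

The change from compound 1 to compound 2 is chloro in place of hydrogen on an aromatic carbon, and the step it made was a 1.0-fold lower number from compound 1 to compound 2 (0.01 log units; within the scatter). Compound 4, `CC(=O)OC/C(=C/c1ccc(Cl)cc1Cl)C(=O)c1ccccc1`, is not yet measured; it differs from compound 3 by chloro in place of hydrogen on an aromatic carbon. This is the same kind of change, though the surroundings differ: in compound 2 the entering chloro sits ortho to a large group, in compound 4 para to a large group. Resting on the step from compound 1 to compound 2, compound 4 is expected to show a 1.1-fold lower number from compound 3 to compound 4 (0.02 log units; within the scatter), landing near 20000 nM.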

Compound 4, concentration for 50% growth inhibition: 23000 nM
Estimate against measurement, compound 4: 1.2-fold (0.06 log units) below, within the range that was stated.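

In this assay, the entering chloro group gave a 1.1-fold higher number from compound 3 to compound 4 (0.04 log units; within the scatter). Set beside the earlier step, the change carried from one core to the other with no difference that can be told apart: the same change on two cores in this assay, a 1.0-fold lower number (0.01 log units; within the scatter) from compound 1 to compound 2 and a 1.1-fold higher number (0.04 log units; within the scatter) from compound 3 to compound 4, 1.1-fold (0.05 log units) apart, within the scatter of two such steps. Among the compounds shown here, this rests on only one pair per core, and it does not show how the change would behave at another place on the aromatic ring or on any other core.

The compounds shown leave open whether a group other than chloro, such as methoxy or an amine, would shift the number on either core at the same aromatic carbon. They also leave open what a hydroxyl or an amine would do on the side chain that carries the acetate ester in compound 3.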